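A few compounds are considered here, and "the series" means these few. Any claim that something is new, unique, unknown or untested is made for them only; others in the source may bear on it.

Compound 1 `CC1CCN(c2c(S(=O)(=O)c3ccc(Cl)c(Cl)c3)cnc3ccc(Cl)cc23)CC1`, compound 2 `COc1cccc(S(=O)(=O)c2cnc3ccc(Cl)cc3c2N2CCC(C)CC2)c1` and compound 3 `CC1CCN(c2c(S(=O)(=O)c3ccc(Cl)c(Cl)c3)cnc3ccc(F)cc23)CC1` share one core and were all tested in an assay on isolated protein for displacement of a labelled ligand from metabotropic glutamate receptor 5 (Homo sapiens), with a stated time of 60 min, tested at 1 uM; a higher number here means more inhibition at the concentration tested (going by the name of the read-out), a lower number less inhibition. In this assay compound 1 gives 86%, compound 2 gives 87% and compound 3 gives 91%. Between compound 1 and compound 2 the change is 3-methoxyphenyl in place of 3,4-dichlorophenyl on a sulfonyl sulfur, and it made a step of a number 1 percentage points higher from compound 1 to compound 2 (within the scatter). Between compound 1 and compound 3 the change is fluoro in place of chloro on an aromatic carbon, with a step of a number 5 percentage points higher from compound 1 to compound 3 (within the scatter). Compound 4 `COc1cccc(S(=O)(=O)c2cnc3ccc(F)cc3c2N2CCC(C)CC2)c1` has not yet been measured; it differs from compound 3 by 3-methoxyphenyl in place of 3,4-dichlorophenyl on a sulfonyl sulfur, the same change as that from compound 1 to compound 2, made at the same place. Because that earlier step was a number 1 percentage points higher from compound 1 to compound 2 (within the scatter), a step of about no change at the digits printed from compound 3 to compound 4 (within the scatter) is expected from compound 3 to compound 4. Compound 4 is therefore estimated at 91%, expected between 80% and 98%.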

Compound 4, a percentage reported as inhibition, at one concentration (the size of the read-out at that concentration, not a potency): 90%
Estimate against measurement, compound 4: 1 percentage points above; the range from low to high includes it.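

In this assay, 3-methoxyphenyl in place of 3,4-dichlorophenyl on a sulfonyl sulfur gave a number 1 percentage points lower from compound 3 to compound 4 (within the scatter), which agrees with the same change on the other core: the same change on two cores in this assay, a number 1 percentage points higher (within the scatter) from compound 1 to compound 2 and a number 1 percentage points lower (within the scatter) from compound 3 to compound 4, 2 percentage points apart, within the scatter of two such steps. Fluoro in place of chloro on an aromatic carbon gave a number 3 percentage points higher from compound 2 to compound 4 (within the scatter), which also agrees with its earlier step: the same change on two cores in this assay, a number 5 percentage points higher (within the scatter) from compound 1 to compound 3 and a number 3 percentage points higher (within the scatter) from compound 2 to compound 4, 2 percentage points apart, within the scatter of two such steps. Within the data shown here, neither change shifted the read-out beyond the usual scatter on either core, but this rests on only two pairs per change, and a single tested concentration gives no potency, so smaller differences in potency could go unseen.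

The compounds shown leave open whether an amine or a carboxylic acid in place of the 3-methoxyphenyl on the sulfonyl sulfur would give the same picture.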